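Replacing the Acid in Compound 3 with a Triazole

The compounds below may be only part of what the source reports. "The series", "measured", "known", "first", "only" and "open" are said of these compounds alone.

Of the compounds shown here, three have so far been measured in an assay on isolated protein for binding affinity to Bombesin receptor subtype-3 (Homo sapiens); a higher number here means a weaker inhibitor, a lower number a stronger inhibitor. Compound 1 `c1ccc(-c2nnn[nH]2)c(-c2ccc(CCc3nc(CC4CCCC4)c[nH]3)cc2)c1` gives 15 nM, and compound 2 `O=C1NC(=O)C(c2ccccc2-c2ccc(CCC3N=CC(CC4CCCC4)=N3)cc2)S1` gives 287 nM. Compound 3 `CCC(C)(C)Cc1c[nH]c(CCc2ccc(-c3ccccc3OCC(=O)O)cc2)n1` gives 103 nM, the second highest number of the three: it sits nearer to compound 2 and further from compound 1, both gaps beyond the usual scatter. Compound 4 `CCC(C)(C)Cc1c[nH]c(CCc2ccc(-c3ccccc3OCc3nc(C(F)(F)F)n[nH]3)cc2)n1` differs from compound 3 in one place: 3-(trifluoromethyl)-1H-1,2,4-triazol-5-yl in place of carboxy on a saturated chain carbon bound to an oxygen on an aromatic ring. Going by the values given here, no measured pair shows this kind of exchange, so the step is an expectation only; a modest move toward a lower number is expected, because compound 1, which also carries a ring-based acidic group, gives 15 nM. The expected step from compound 3 to compound 4 is a 2.3-fold lower number from compound 3 to compound 4 (0.36 log units; beyond the scatter). Compound 4 is estimated at 45 nM, with a range from 12 nM to 170 nM.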

Compound 4, half-maximal inhibitory concentration: 127 nM
Compound 4: middle estimate off by 2.8-fold (0.45 log units), on the low side, within the range that was stated.
By their numbers in this assay, from the lowest: compound 1; then compounds 3 and 4 (each within the scatter of the next); then compound 2.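

Exchanging carboxy for 3-(trifluoromethyl)-1H-1,2,4-triazol-5-yl on this saturated chain carbon gives a 1.2-fold higher number from compound 3 to compound 4 (0.09 log units; within the scatter). So at this position, a group with 9 heavy atoms and a five-membered aromatic ring stands in for one with 3 heavy atoms and no ring, without a readable change in this assay. No measurement shown here explains why the two groups read alike.

From the compounds shown here alone, it remains open how a primary amide or a methyl ester would read at this place. The same goes for a triazole without its trifluoromethyl.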